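This account rests on a few compounds, and the source may have more. Where it says the series, first, only, none or still open, it means among the compounds named here.

Working notes on the series. Three compounds carry numbers in an assay on liver for inhibition of sterol O-acyltransferase 1 (Rattus norvegicus), using microsomes; on this read-out lower numbers stand for stronger inhibition and higher numbers for weaker inhibition. Compound 1 (`CC(C)c1cccc(C(C)C)c1NC(=O)NS(=O)(=O)N1CCC(c2ccccc2)CC1`) gives 10400 nM in this assay. Compound 2 (`CC(C)c1cccc(C(C)C)c1NS(=O)(=O)NC(=O)NC(c1ccccc1)c1ccccc1`) gives 30000 nM in this assay. Compound 3 (`CC(C)c1cccc(C(C)C)c1OS(=O)(=O)NC(=O)OC1CCCCC1`) gives 38000 nM in this assay, the highest number of the three; its gap to compound 2 is within the usual scatter, so the two cannot be ordered, while compound 1 sits beyond the scatter at the lower, stronger end. Among the measured compounds shown here, no pair of these three differs in a single place, so no step between measured compounds can be read off.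

Compound 4 (`CC(C)c1cccc(C(C)C)c1OS(=O)(=O)NC(=O)Oc1c(F)cccc1F`) is the unmeasured one. It differs from compound 3 by 2,6-difluorophenyl in place of cyclohexyl on an oxygen next to a carbonyl group. Nothing in the measured set shows what such an exchange does in this assay; all three measured compounds lie in a narrow band at the weak end. For the measured compounds named here, with no comparable step to lean on, the expectation for this change is no step beyond the scatter, in either direction, and the estimated move reads a 1.3-fold lower number from compound 3 to compound 4 (0.10 log units; within the scatter). For compound 4 the estimate in this assay is therefore 30000 nM, with a range from 10000 nM to 90000 nM.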

Compound 4, half-maximal inhibitory concentration: 65000 nM
Estimate against measurement, compound 4: 2.2-fold (0.34 log units) below; the measured number falls inside the stated range.
By their numbers in this assay, from the lowest: compound 1; then compounds 2, 3 and 4 (each within the scatter of the next, the first and the last beyond it).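

In this assay the exchange of cyclohexyl for 2,6-difluorophenyl on an oxygen next to a carbonyl group gives a 1.7-fold higher number from compound 3 to compound 4 (0.23 log units; within the scatter) and so stays within the scatter. Among the compounds shown here, this is the first single-place step available, and at this position it does not separate a six-membered non-aromatic ring of carbon only from a six-membered aromatic ring carrying two fluorine atoms. Nothing measured on these compounds accounts for this outcome.

For the compounds shown here, the single step does not show whether any other group on this oxygen would move the number beyond the scatter, and a straight hexyl chain or a chain ending in an amine would test this more widely than another six-membered ring. It also leaves open whether the exchange would read the same on the core of compound 1 or the core of compound 2, and the contributions of the ring change and the two fluorine atoms cannot be separated here.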